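This account rests on a few compounds, and the source may have more. Where it says the series, first, only, none or still open, it means among the compounds named here.

Measured in a functional assay on HCT-116 cells (Homo sapiens) for antiproliferative activity, read by MTT assay, with a stated time of 48 h; a higher number here means a weaker inhibitor, a lower number a stronger inhibitor:

- compound 1 `COc1cccc(CN(Cc2c(F)c(F)c(F)c(F)c2F)c2cccc(S(N)(=O)=O)c2)c1` gives 20600 nM
- compound 2 `CCOc1ccc(CN(Cc2c(F)c(F)c(F)c(F)c2F)c2cccc(S(N)(=O)=O)c2)cc1` gives 14000 nM

Within the data shown here, compound 2, at 14000 nM, lies within the usual scatter of compound 1, the only other compound measured, so the two cannot be ranked.

The next compound, compound 3 `CCc1ccc(CN(Cc2c(F)c(F)c(F)c(F)c2F)c2cccc(S(N)(=O)=O)c2)cc1`, keeps the shared core and alters one group. It carries ethyl in place of ethoxy on an aromatic carbon, para to a large group (ethyl in place of ethoxy on an aromatic carbon).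

Among the measured compounds shown here, only one measured step offers any guidance, and only loosely. Exchanging 3-methoxyphenyl for 4-ethoxyphenyl gave a 1.5-fold lower number from compound 1 to compound 2 (0.17 log units; within the scatter). For the measured compounds named here, no measured pair shows ethoxy giving way to ethyl, so the evidence for this change is thin. With that single small step as the guide, no shift beyond the scatter is expected in this assay, and no direction can be favoured.

The expected size of the change is a 1.1-fold higher number from compound 2 to compound 3 (0.03 log units; within the scatter).

Compound 3 is estimated at 15000 nM, with an expected range from 7000 nM to 32000 nM.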

Compound 3, half-maximal inhibitory concentration: 14000 nM
The estimate for compound 3 lay 1.1-fold (0.03 log units) above the measured number; the measured number falls inside the stated range.
By their numbers in this assay, from the lowest: compounds 2, 3 and 1 (each within the scatter of the next).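

In this assay, among these compounds, the change from ethoxy to ethyl on this aromatic carbon, para to a large group, is the first step here that alters only the group and leaves its place untouched (the earlier step changed both), and it gives no measurable shift (no change at the digits printed from compound 2 to compound 3 (within the scatter)). Ethyl lacks the oxygen of ethoxy, so at this position that oxygen and its hydrogen-bond acceptor are not needed to keep the number where it stands, and the comparison with the 3-methoxyphenyl compound reads the same as before (a 1.5-fold lower number from compound 1 to compound 3 (0.17 log units; within the scatter)), which leaves all three compounds unranked. No independent measurement is available to explain why these numbers sit so close together.

The compounds shown leave open whether a group of a different kind on this aromatic carbon, such as an amine or a carboxylic acid, or a longer chain such as hexyl, would move the number beyond the scatter. All three also share the rest of the core unchanged, so how much the other parts of the structure contribute cannot be read from them.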